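This account rests on a few compounds, and the source may have more. Where it says the series, first, only, none or still open, it means among the compounds named here.

Compounds with measured values in an ADME assay on MT4 cells (Homo sapiens) for cytotoxicity; a lower number here means that less compound is tolerated, a higher number that more compound is tolerated:
compound 1 `Cc1cc(C)cc(S(=O)(=O)n2c(=S)[nH]c3ccccc32)c1` gives 41000 nM
compound 2 `Cc1cc(C)cc(S(=O)(=O)n2c(=S)[nH]c3ccc(Cl)cc32)c1` gives 93100 nM
compound 3 `Cc1cc(C)cc(Cn2c(SCC(=O)Nc3ccc(S(C)(=O)=O)cc3Cl)nc3ccccc32)c1` gives 106000 nM

Between compound 1 and compound 2 the change is chloro in place of hydrogen on an aromatic carbon, and in this assay it gave a 2.3-fold higher number from compound 1 to compound 2 (0.36 log units; beyond the scatter). How the core of compound 3 differs from the core of compound 1 is not broken down here. Compound 3 stands closest to compound 2, within the scatter, and beyond the scatter of compound 1. Compound 4 `Cc1cc(C)cc(Cn2c(SCC(=O)Nc3ccc(S(C)(=O)=O)cc3Cl)nc3ccc(Cl)cc32)c1` has not yet been measured; it differs from compound 3 by chloro in place of hydrogen on an aromatic carbon, the same change as between compound 1 and compound 2. On the strength of a 2.3-fold higher number from compound 1 to compound 2 (0.36 log units; beyond the scatter), a step of a 1.8-fold higher number from compound 3 to compound 4 (0.25 log units; within the scatter) is expected in this assay. Compound 4 is therefore estimated at 190000 nM, between 95000 nM and 380000 nM.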

Compound 4, half-maximal cytotoxic concentration: 88800 nM
Compound 4: the middle estimate sits 2.1-fold (0.33 log units) above what was measured; measured number outside the range, below it.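

In this assay, chloro in place of hydrogen on an aromatic carbon did not carry over in size from one core to the other: the same change on two cores in this assay, a 2.3-fold higher number (0.36 log units; beyond the scatter) from compound 1 to compound 2 and a 1.2-fold lower number (0.08 log units; within the scatter) from compound 3 to compound 4, 2.7-fold (0.43 log units) apart, beyond the scatter of two such steps. On the core of compound 3 the change gave a 1.2-fold lower number from compound 3 to compound 4 (0.08 log units; within the scatter), so the rise seen on the core of compound 1 did not recur there. With one pair per core, this shows that the step differed between these two cores, but not which feature of the cores accounts for that, nor how it would run on any further core.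

The compounds shown carry only hydrogen or chloro at this place, so how fluoro, methoxy or an amine would behave there on either core stays open. Going by these compounds, whether such groups would also differ between the two cores is equally open.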